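Notes on the series: from compound 3 to compound 4

The source may report more compounds than this note shows. Statements on the series, on what has been measured and on what is new or still open speak of the compounds shown alone.

Values in a functional assay on HeLa cells (Homo sapiens) for antiproliferative activity, read by CCK-8 assay, with a stated time of 48 h (a higher number here means a weaker inhibitor, a lower number a stronger inhibitor), so far
compound 1 `COc1ccc(/C=C\c2cc(OC)c(OC)c(OC)c2)cc1OCc1ccc(CN2C[C@H](O)C[C@@H]2C(=O)O)cc1` gives > 10000 nM
compound 2 `COc1ccc(/C=C\c2cc(OC)c(OC)c(OC)c2)cc1OCc1ccc(CN2CCCC[C@H]2C(=O)O)cc1` gives > 10000 nM
compound 3 `COc1ccc(/C=C\c2cc(OC)c(OC)c(OC)c2)cc1OCc1ccc(CN2CCCC[C@@H]2C(=O)O)cc1` gives > 10000 nM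

For compound 3 the entry > 10000 nM is a limit and not a number, and the entries for the other two compounds are limits as well. Compound 4 `COc1ccc(/C=C\c2cc(OC)c(OC)c(OC)c2)cc1OCc1ccc(CN2CCCCC2C(=O)O)cc1` differs from compound 3 as follows: the two compounds have the same atoms and bonds; at least one stereo element is drawn with a configuration in one of them and without one in the other: 1 of 2 stereo elements differ; a stereocentre at a saturated ring carbon is drawn R in compound 3 and without a configuration in compound 4. The nearest measured step is a step that the two limits leave unreadable from compound 2 to compound 3, which concerns the same stereocentre and has no readable size. What bears on it is the limit of > 10000 nM in this assay, at which 3 of the 3 values shown sit, together with the fact that compounds 2 and 3 differ only in the configuration as drawn. No step beyond the scatter is therefore expected in this assay, and no direction can be given. The expected step is a step that the limit leaves unreadable from compound 3 to compound 4, so no real change is anticipated. For compound 4 the estimate is 15000 nM, with an expected range of 6000 nM to 40000 nM, and another limit is the likely report.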

Compound 4, half-maximal inhibitory concentration: 14200 nM
Beside the measured number, compound 4's estimate is 1.1-fold (0.02 log units) above it, within the range that was stated.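

The steps to compound 4 from compound 1, compound 2 and compound 3 cannot be read: those three values are limits, not numbers. Left open is whether the configuration drawn S in compound 2 and R in compound 3 matters at all.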